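Swapping a Cyclohexyl Ether for a Dinitrophenyl Ether

A few compounds are considered here, and "the series" means these few. Any claim that something is new, unique, unknown or untested is made for them only; others in the source may bear on it.

In a functional assay on HeLa cells (Homo sapiens) for inhibition, read by CCK-8 assay, with a stated time of 48 h (on this read-out higher numbers stand for weaker inhibition and lower numbers for stronger inhibition), compound 1 `O=C(NCCNS(=O)(=O)c1ccc(-c2ccccc2O[C@H]2CC[C@H](O)CC2)s1)Nc1cc(C(F)(F)F)cc(C(F)(F)F)c1` reads > 20000 nM. That value is a limit of the assay and not a number.

Going by the values given here, compound 2 `O=C(NCCNS(=O)(=O)c1ccc(-c2ccccc2O[C@H]2CC[C@@H](O)CC2)s1)Nc1cc(C(F)(F)F)cc(C(F)(F)F)c1` gives 14100 nM, the only true number so far, so it is the sole firm reference point for what follows.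

The next structure is compound 3 `O=C(NCCNS(=O)(=O)c1ccc(-c2ccccc2Oc2ccc([N+](=O)[O-])c([N+](=O)[O-])c2)s1)Nc1cc(C(F)(F)F)cc(C(F)(F)F)c1`. The change is 3,4-dinitrophenyl in place of 4-hydroxycyclohexyl on an oxygen on an aromatic ring, which means 3,4-dinitrophenyl in place of 4-hydroxycyclohexyl on an oxygen on an aromatic ring.

Among the compounds with values here, only one measured step exists, an at least 1.4-fold lower number from compound 1 to compound 2 (0.15 log units; that floor lies within the scatter). It rests on the limit of > 20000 nM in this assay, at which 1 of the 2 values shown sits, and on (the fact that compounds 1 and 2 differ only in the configuration as drawn). It therefore concerns only the configuration of the 4-hydroxycyclohexyl group that now leaves, and it offers no measured guide to replacing that whole group.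

With so little to go on, no step beyond the scatter is expected, although the uncertainty is wide. The expected change is a 1.4-fold lower number from compound 2 to compound 3 (0.15 log units; within the scatter).

For compound 3, the estimate is 10000 nM, with an expected range from 3000 nM to 20000 nM.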

Compound 3, half-maximal inhibitory concentration: > 50000 nM
Compound 3: only a limit was reported (the forecaster's own chance of this, stated with the estimate: 35%); at least 5.0-fold (0.69 log units) between middle value and limit.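

In this assay, replacing 4-hydroxycyclohexyl on this oxygen with 3,4-dinitrophenyl gives an at least 3.5-fold higher number from compound 2 to compound 3 (0.54 log units; beyond the scatter), and on this read-out a higher number means weaker inhibition. Going by these compounds alone, the earlier pair differed only in configuration, so this is the first view of what happens when the whole group is exchanged, and it shows that this position does not accept every group: the exchange goes toward weaker inhibition, not toward stronger. The value of compound 3 is a limit of the assay and not a number, and the step can only be given as a floor because of it: the limit of > 50000 nM in this assay, at which 1 of the 3 values shown sits.

The step from compound 1 to compound 3 cannot be read, as limits stand at both of its ends. Going by these compounds, the exchange also alters two things at once, the ring and its substituents, so it remains open whether the weaker inhibition goes with the aromatic ring or with the two nitro groups, a question that a plain phenyl, a phenyl carrying one nitro group or a 4-aminocyclohexyl group at this oxygen could help to settle.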